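The compounds below may be only part of what the source reports. "The series", "measured", "known", "first", "only" and "open" are said of these compounds alone.

Of the compounds shown here, two on the shared core have been measured so far. In a functional assay on A549 cells (Homo sapiens) for cytotoxicity, read by MTT assay, with a stated time of 72 h (on this read-out lower numbers stand for stronger inhibition and higher numbers for weaker inhibition), compound 1 (`O=S(=O)(c1ccc(F)cc1)c1nc2ccccc2nc1N1CCCC1`) gives 31100 nM, while compound 2 (`COc1ccc(S(=O)(=O)c2nc3ccccc3nc2N2CCCC(O)C2)cc1`) gives 2180 nM, the lower of the two numbers and clearly beyond the scatter. Compound 3 (`O=S(=O)(c1ccc(F)cc1)c1nc2ccccc2nc1N1CCCC(O)C1`) has not yet been measured. It departs from compound 2 in one place: fluoro in place of methoxy on an aromatic carbon, with fluoro in place of methoxy on an aromatic carbon, that is, 4-methoxyphenyl to 4-fluorophenyl. The 4-fluorophenyl group also occurs in compound 1, at 31100 nM, but that compound differs elsewhere as well, so the data do not isolate this change. Only a modest rise in the number is therefore expected, near the edge of the scatter, and the expected step is a 2.1-fold higher number from compound 2 to compound 3 (0.31 log units; beyond the scatter). For compound 3 the estimated value is 4500 nM, with an expected range from 1500 nM to 13000 nM.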

Compound 3, half-maximal inhibitory concentration: 8170 nM
The estimate for compound 3 lay 1.8-fold (0.26 log units) below the measured number, within the range that was stated.
By their numbers in this assay, from the lowest: compound 2; then compound 3; then compound 1.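

In this assay, the change from 4-methoxyphenyl to 4-fluorophenyl can now be read on its own, with the rest of the structure held fixed: fluoro in place of methoxy gives a 3.7-fold higher number from compound 2 to compound 3 (0.57 log units; beyond the scatter). The other place can be read as well: with 4-fluorophenyl held fixed, 3-hydroxypiperidin-1-yl in place of pyrrolidin-1-yl gives a 3.8-fold lower number from compound 1 to compound 3 (0.58 log units; beyond the scatter). No measurement given here bears on why either change moves the number.

The compounds shown hold only methoxy and fluoro on this aromatic carbon, so how a chloro or a dimethylamino group would rank there stays open. With only pyrrolidin-1-yl and 3-hydroxypiperidin-1-yl at the other place, a plain piperidin-1-yl group would be needed to separate the hydroxyl from the change of ring.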